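This account rests on a few compounds, and the source may have more. Where it says the series, first, only, none or still open, it means among the compounds named here.

Compound 1 `O=C1C2=C(CCCC2)C(=O)N1c1ccc(Cl)cc1F` gives 37.2 nM
Compound 2 `CC(C)OC(=O)c1cc(N2C(=O)C3=C(CCCC3)C2=O)c(F)cc1Cl` gives 13.8 nM

Among the measured compounds shown here, in a functional assay on the whole organism for inhibition, with Scenedesmus acutus as the target (on this read-out lower numbers stand for stronger inhibition and higher numbers for weaker inhibition), compound 2, at 13.8 nM, holds the lower of the two numbers so far. Compound 3 `CCC(C)OC(=O)c1cc(N2C(=O)C3=C(CCCC3)C2=O)c(F)cc1Cl` differs from it by one small change: methyl in place of hydrogen on a saturated chain carbon, two bonds along the chain from an oxygen next to a carbonyl group. This turns isopropoxy to sec-butoxy. For the measured compounds named here, only one measured step bears on this change, and it was modest: a 2.7-fold lower number from compound 1 to compound 2 (0.43 log units; beyond the scatter), when isopropoxycarbonyl took the place of hydrogen on an aromatic carbon. Adding methyl is a smaller edit, so the expected change is none beyond the scatter, in no firm direction: a 1.0-fold higher number from compound 2 to compound 3 (0.01 log units; within the scatter). The estimate for compound 3 is 14 nM, with an expected range from 6 nM to 32 nM.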

Compound 3, half-maximal inhibitory concentration: 60.3 nM
Beside the measured number, compound 3's estimate is 4.3-fold (0.63 log units) below it; the measured number lies above the stated range.
By their numbers in this assay, from the lowest: compound 2; then compounds 1 and 3 (each within the scatter of the next).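

The saturated chain carbon two bonds along from the oxygen tolerates little here: one added methyl, turning isopropoxy into sec-butoxy, gives a 4.4-fold higher number from compound 2 to compound 3 (0.64 log units; beyond the scatter), a larger shift than the opening step suggested. With sec-butoxycarbonyl, the comparison with the hydrogen of compound 1 reads a 1.6-fold higher number from compound 1 to compound 3 (0.21 log units; within the scatter), so the advantage held by isopropoxycarbonyl is not kept. No measured evidence accounts for this result.

From the compounds shown here alone, whether ethoxycarbonyl or tert-butoxycarbonyl would fare better remains open. So does the outcome with a carboxylic acid in place of isopropoxycarbonyl.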